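A few compounds are considered here, and "the series" means these few. Any claim that something is new, unique, unknown or untested is made for them only; others in the source may bear on it.

Among the compounds with values here, in a functional assay on HeLa cells (Homo sapiens) for inhibition, with a stated time of 72 h (on this read-out higher numbers stand for weaker inhibition and lower numbers for stronger inhibition), compound 1 `NC1CCC(Nc2nc(NCc3ccc(-c4ccccc4)nc3)c3ncn(C4CCCC4)c3n2)CC1` gives 114 nM and compound 2 `NC1CCC(Nc2nc(NCc3ccc(-c4cccs4)nc3)c3ncn(C4CCCC4)c3n2)CC1` gives 40 nM, the lower of the two numbers so far. Next in the series is compound 3 `NC1CCC(Nc2nc(NCc3ccc(-c4ccccc4O)nc3)c3ncn(C4CCCC4)c3n2)CC1`, with the change (2-hydroxyphenyl in place of thiophen-2-yl on an aromatic carbon). The entering 2-hydroxyphenyl is a six-membered aromatic ring of carbon only, like the phenyl of compound 1. Within the data shown here, the one measured step therefore bears on this change when read in reverse: a 2.9-fold lower number from compound 1 to compound 2 (0.45 log units; beyond the scatter), a modest step beyond the scatter. Among the measured compounds shown here, no measured compound carries 2-hydroxyphenyl, so what that substituent adds to a phenyl stays open. A modest move towards a higher number in this assay is expected, of similar size to the measured step or somewhat smaller. The expected step is a 2.3-fold higher number from compound 2 to compound 3 (0.35 log units; beyond the scatter). The estimate for compound 3 is 90 nM, with an expected range of 30 nM to 270 nM.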

Compound 3, half-maximal inhibitory concentration: 16 nM
Estimate against measurement, compound 3: 5.6-fold (0.75 log units) above; measured number below the stated range.
By their numbers in this assay, from the lowest: compound 3; then compound 2; then compound 1.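

In this assay, hydroxy on the phenyl gives a 7.1-fold lower number from compound 1 to compound 3 (0.85 log units; beyond the scatter), so this place on the aromatic carbon next to the ring nitrogen responds strongly to a single added group. The 2-hydroxyphenyl also improves on the thiophen-2-yl, with a 2.5-fold lower number from compound 2 to compound 3 (0.40 log units; beyond the scatter), which puts the three groups in the order 2-hydroxyphenyl, thiophen-2-yl, phenyl, from the lowest number. Ring type alone therefore does not set the number: compound 1 and compound 3 both carry a six-membered aromatic ring of carbon only, yet they stand at opposite ends of this short series.

As far as these compounds go, whether a methoxy or an amine in place of the hydroxy would hold the gain stays open, as does the effect of a hydroxy on the thiophene. Nothing on hand explains the gain from the hydroxy.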